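Alkynyl thiazoles: carbamate in place of amine

A few compounds are considered here, and "the series" means these few. Any claim that something is new, unique, unknown or untested is made for them only; others in the source may bear on it.

Measured so far:
- compound 1 `Cc1nc(C#Cc2cccc(C(F)(F)F)c2)cs1`: 413 nM
- compound 2 `Cc1nc(C#Cc2ccsc2)cs1`: 337 nM
- compound 3 `Nc1nc(C#Cc2cccnc2)cs1`: 789 nM

In a functional assay on CHO cells for agonist activity at metabotropic glutamate receptor 5 (Homo sapiens), read by inositol phosphate accumulation (on this read-out lower numbers stand for stronger inhibition and higher numbers for weaker inhibition), compound 3 gives the highest of the three numbers. Against compound 1 the gap is within the scatter, so the two cannot be set apart; against compound 2 the gap lies beyond the scatter, and compound 2 shows the lower number of the pair. For the measured compounds named here, no two of the measured compounds differ in a single place, so no step has been measured.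

Compound 4 `COC(=O)Nc1nc(C#Cc2cccnc2)cs1` is the next compound to be run in this assay. Relative to compound 3 it carries methoxycarbonyl in place of hydrogen on a nitrogen on an aromatic ring. Going by the values given here, no measured compound shows what a change on this nitrogen does, and the three amine-bearing or methyl-bearing analogues offer no direct guide. The expected step from compound 3 to compound 4 is therefore small, a 1.2-fold lower number from compound 3 to compound 4 (0.08 log units; within the scatter), with no clear direction beyond the scatter. The estimate for compound 4 in this assay is 650 nM, within a range of 150 nM to 2800 nM.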

Compound 4, half-maximal inhibitory concentration: > 10000 nM
Compound 4: a limit, no number; the forecaster's own chance of this, stated with the estimate: 10%; at least 15-fold (1.18 log units) between middle value and limit.
By their numbers in this assay, from the lowest: compounds 2, 1 and 3 (each within the scatter of the next, the first and the last beyond it). At a limit, above all of these: compound 4.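

For the compounds shown here, this is the first change read at the nitrogen on an aromatic ring, and amino to (methoxycarbonyl)amino gives an at least 12-fold higher number from compound 3 to compound 4 (1.10 log units; beyond the scatter) in this assay. In this assay compound 4 gives > 10000 nM, which is a limit of the assay and not a number. The step therefore fixes only a lower bound on the size of the change, and its true size stays unknown: the limit of > 10000 nM in this assay, at which 1 of the 4 values shown sits.

One step cannot show how much of the change belongs to the carbonyl and how much to the methoxy end of the methoxycarbonyl group. From the compounds shown here alone, it remains open whether a methyl or acetyl group on this nitrogen would keep a value close to that of compound 3, or whether a longer ethoxycarbonyl group would behave like methoxycarbonyl.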